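Sulfanyl for propyl on the shared core

A few compounds are considered here, and "the series" means these few. Any claim that something is new, unique, unknown or untested is made for them only; others in the source may bear on it.

Compound 3 `CCCc1nc(N)c2nc(O)n(Cc3ccccc3)c2n1` stands in the middle of the three measured compounds in a functional assay (spleen, spleen) for activation, with Mus musculus as the target; a higher number here means that more compound is needed for the effect, a lower number that less compound is needed: compound 3 gives 1 uM. Compound 1 `CCCCCNc1nc(N)c2nc(O)n(Cc3ccccc3)c2n1`, with pentylamino on the same aromatic carbon, gives 0.1 uM, and compound 2 `Nc1ncnc2c1nc(O)n2Cc1ccccc1`, with hydrogen there, gives 10 uM. Compound 4 `Nc1nc(S)nc2c1nc(O)n2Cc1ccccc1` differs from compound 3 in one place: sulfanyl in place of propyl on an aromatic carbon. The change sits on the aromatic carbon between two ring nitrogen atoms, the same position varied across the measured set. Going by the values given here, no measured step exchanges a propyl for a sulfanyl, so the steps that bear on it are those at this carbon: a 10-fold lower number from compound 2 to compound 3 (1.00 log units; beyond the scatter) and a 10-fold higher number from compound 1 to compound 3 (1.00 log units; beyond the scatter), with a 100-fold higher number from compound 1 to compound 2 (2.00 log units; beyond the scatter) spanning both. Removing the propyl altogether was a modest step; sulfanyl is not hydrogen, yet the data hold no anchor for it, so the outcome is taken to lie toward compound 2. A modest step upward in number is expected for compound 4: a 5.0-fold higher number from compound 3 to compound 4 (0.70 log units; beyond the scatter). Compound 4 is therefore estimated at 5 uM, with a range of 1 uM to 30 uM.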

Compound 4, minimum effective concentration: 10 uM
Beside the measured number, compound 4's estimate is 2.0-fold (0.30 log units) below it, within the range that was stated.
By their numbers in this assay, from the lowest: compound 1; then compound 3; then compounds 2 and 4 (each within the scatter of the next).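

At the aromatic carbon between two ring nitrogen atoms, sulfanyl does not keep the level of propyl in this assay, with a 10-fold higher number from compound 3 to compound 4 (1.00 log units; beyond the scatter). Sulfanyl and hydrogen cannot be told apart at this carbon, with no change at the digits printed from compound 2 to compound 4 (within the scatter), while pentylamino remains clearly separated from sulfanyl, with a 100-fold higher number from compound 1 to compound 4 (2.00 log units; beyond the scatter). Nothing given here explains the sulfanyl result.

The compounds shown leave open whether the difference between pentylamino and propyl follows the linking amine or the longer chain, and a propylamino or a pentyl group at this carbon would separate the two. As far as these compounds go, it is also open whether sulfanyl carrying a butyl chain would stay with hydrogen or move towards propyl or pentylamino.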